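This account rests on a few compounds, and the source may have more. Where it says the series, first, only, none or still open, it means among the compounds named here.

Compound 1 `CCCCCCCCSC(=O)CS(=O)(=O)Nc1c(C(C)C)cccc1C(C)C` and compound 2 `CCCCCCCCCCCCSC(=O)CS(=O)(=O)Nc1c(C(C)C)cccc1C(C)C` share one core and differ only in the length of the chain on the thioester sulfur. In an assay on microsomes from intestine for inhibition of acyl-CoA:cholesterol acyltransferase (Oryctolagus cuniculus) (on this read-out lower numbers stand for stronger inhibition and higher numbers for weaker inhibition), compound 1 gives 150 nM, and compound 2 gives 73 nM. That single step, a 2.1-fold lower number from compound 1 to compound 2 (0.31 log units; beyond the scatter), came from butyl in place of hydrogen on a saturated chain carbon, eight bonds along the chain from a sulfur. On the two numbers shown, compound 2 stands lowest, and its only neighbour is compound 1, which sits higher by a step beyond the scatter.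

Compound 3 `CCCCCCCCCCCCCCCCCCSC(=O)CS(=O)(=O)Nc1c(C(C)C)cccc1C(C)C` carries the same core and extends the chain once more: hexyl in place of hydrogen on a saturated chain carbon, ten or more bonds along the chain from a sulfur. Going by the values given here, the one measured step that bears on it is the chain extension from compound 1 to compound 2, which was modest but beyond the scatter. Since a longer chain already gave the lower number, compound 3 is expected to move in the same direction, though with less confidence that the gain continues at the same rate; the expected step is a 1.5-fold lower number from compound 2 to compound 3 (0.16 log units; within the scatter). Compound 3 is therefore estimated at 50 nM in this assay, within a range from 20 nM to 150 nM.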

Compound 3, half-maximal inhibitory concentration: > 5000 nM
Compound 3: only a limit was reported (the forecaster's own chance of this, stated with the estimate: 3%); at least 100-fold (2.00 log units) between middle value and limit.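

Lengthening the chain on the thioester sulfur does not keep lowering the number in this assay: hexyl in place of hydrogen on a saturated chain carbon, ten or more bonds along the chain from a sulfur, brings an at least 68-fold higher number from compound 2 to compound 3 (1.83 log units; beyond the scatter). The longest chain also falls behind the shortest of the three, with decyl in place of hydrogen giving an at least 33-fold higher number from compound 1 to compound 3 (1.52 log units; beyond the scatter), so this position tolerates extension only up to a point, and the direction of a 2.1-fold lower number from compound 1 to compound 2 (0.31 log units; beyond the scatter) holds for compound 1 and compound 2 while compound 3 goes against it. Compound 3 is reported only as a limit, not as a number: the limit of > 5000 nM in this assay, at which 1 of the 3 values shown sits.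

What remains open is the chain length between those of compound 2 and compound 3 at which the number turns upward, and what value lies behind the limit of compound 3. Also open, on these data alone, is whether a chain as long as that of compound 3 but ending in a carboxylic acid or an amine would behave in the same way.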